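Swapping the sulfonyl aryl group in a benzoxazole sulfonamide

A few compounds are considered here, and "the series" means these few. Any claim that something is new, unique, unknown or untested is made for them only; others in the source may bear on it.

Compound 1, `O=S(=O)(Nc1ccc2oc(-c3ccccc3)nc2c1)c1cccc(F)c1`: > 63000 nM
Compound 2, `O=S(=O)(Nc1ccc(-c2nc3ccccc3o2)cc1)c1cccc(O)c1`: > 63000 nM
Compound 3, `O=S(=O)(Nc1ccc(-c2nc3ccccc3o2)cc1)c1cccs1`: > 63000 nM

In an assay on isolated protein for inhibition of malate dehydrogenase, mitochondrial (Sus scrofa), with stated times of 45 min and 30 min (a lower number here means a stronger inhibitor, a higher number a weaker inhibitor), compound 1 gives > 63000 nM, which is a limit of the assay and not a measured number. Compound 2 likewise gives > 63000 nM, a limit. Compound 3 gives > 63000 nM, again a limit. Going by the values given here, all three sit at the limit of > 63000 nM in this assay, at which 3 of the 3 values shown sit, so none of them shows readable inhibition, and the one single-point step, a step that the two limits leave unreadable from compound 2 to compound 3, cannot be read because both ends are limits.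

Compound 4, `COc1ccc(Cl)cc1S(=O)(=O)Nc1ccc2oc(-c3ccccc3)nc2c1`, differs from compound 1 only at the sulfonyl sulfur: 5-chloro-2-methoxyphenyl in place of 3-fluorophenyl on a sulfonyl sulfur. Among the compounds with values here, no measured step touches this change, and no measured compound in the set gives a number below the limit, so nothing here suggests that this exchange would lift the compound into the readable range. The expected outcome is that compound 4 also sits at the limit, with the step that the limit leaves unreadable from compound 1 to compound 4 expected to be essentially none beyond the scatter. Compound 4 is therefore estimated at 100000 nM, in the range 30000 nM to 400000 nM.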

Compound 4, half-maximal inhibitory concentration: > 63000 nM
Compound 4 was reported as a limit; the forecaster's own chance of this, stated with the estimate: 85%; the middle value does not contradict the limit.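

No new step can be read: compound 1 and compound 4 are both reported only as limits, so 5-chloro-2-methoxyphenyl in place of 3-fluorophenyl has no readable size. The compounds shown leave open whether any group on the sulfonyl sulfur gives readable inhibition, because all of them stand at one limit: the limit of > 63000 nM in this assay, at which 4 of the 4 values shown sit.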